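Swapping dimethylamino for acetyl on the shared core

A few compounds are considered here, and "the series" means these few. Any claim that something is new, unique, unknown or untested is made for them only; others in the source may bear on it.

Compound 1 `O=C(O)c1cnc2cc(OCc3cccc4ccccc34)ccc2c1O`: 85100 nM
Compound 2 `CN(C)c1ccc2c(O)c(C(=O)O)cnc2c1`: 468000 nM

In a functional assay on Ehrlich cells (Mus musculus) for inhibition (on this read-out higher numbers stand for weaker inhibition and lower numbers for stronger inhibition), compound 2, at 468000 nM, has the higher of the two numbers. It stands beyond the scatter from compound 1, which gives 85100 nM, so compound 2 is the weaker inhibitor of the pair.

Compound 3 `CC(=O)c1ccc2c(O)c(C(=O)O)cnc2c1` keeps the core of compound 2 but carries acetyl in place of dimethylamino on an aromatic carbon. Among the compounds with values here, the two measured compounds differ in more than one place, so the data offer no measured step for this exchange. The expectation therefore stays close to compound 2 at 468000 nM. The estimated change is a 1.3-fold higher number from compound 2 to compound 3 (0.11 log units; within the scatter), a slight rise in this assay that is expected to stay within the scatter. For compound 3 the expected value is 600000 nM, with an estimated range from 250000 nM to 1400000 nM.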

Compound 3, half-maximal inhibitory concentration: 794000 nM
The estimate for compound 3 lay 1.3-fold (0.12 log units) below the measured number, and the stated range covers the measured number.
By their numbers in this assay, from the lowest: compound 1; then compounds 2 and 3 (each within the scatter of the next).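

In this assay, within the data shown here, the exchange of dimethylamino for acetyl on an aromatic carbon gives a 1.7-fold higher number from compound 2 to compound 3 (0.23 log units; within the scatter) and so provides the first step at this position that can be read from a single change. Replacing dimethylamino with acetyl, two groups with the same count of heavy atoms but with a nitrogen giving way to an oxygen and a double bond entering outside the aromatic rings, leaves the two compounds within the scatter of each other on this read-out. No measured evidence here bears on why the exchange reads this way.

As far as these compounds go, whether a primary amine, a carboxylic acid or a longer alkyl chain on this aromatic carbon would move the number beyond the scatter remains open. Also open, from the compounds shown here alone, is whether the same exchange would read alike on another core.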